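Pyrrolidin-1-yl to 3-(Dimethylamino)propyl: Expected Lipophilicity

The source may report more compounds than this note shows. Statements on the series, on what has been measured and on what is new or still open speak of the compounds shown alone.

compound 1, `COc1cc(/C=C/C(=O)Nc2ccccc2)ccc1OCCCN1CCCC1`: 1.57
compound 2, `COc1cc(/C=C/C(=O)Nc2ccccc2)ccc1OCCCCCN1CCCCC1`: 1.65

Among the measured compounds shown here, in a physicochemical assay for lipophilicity, using the shake flask method, measured as octanol-water partition, at pH 7.4 (on this read-out higher numbers stand for higher lipophilicity and lower numbers for lower lipophilicity), compound 1 stands at 1.57, and compound 2 stands at 1.65, the only other number. For the measured compounds named here, the one measured step is a number 0.08 log units higher from compound 1 to compound 2 (within the scatter). Compound 3, `COc1cc(/C=C/C(=O)Nc2ccccc2)ccc1OCCCCCCN(C)C`, has not yet been measured. It differs from compound 1 in one place: 3-(dimethylamino)propyl in place of pyrrolidin-1-yl on a saturated chain carbon, three bonds along the chain from an oxygen on an aromatic ring. The measured step bears on this only loosely, since a change in the amine end of the chain moved the number within the scatter. No step beyond the scatter is therefore expected in this assay. Compound 3 is estimated at 1.65, between 1.25 and 2.05. That estimate means a number 0.08 log units higher from compound 1 to compound 3 (within the scatter).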

Compound 3, partition coefficient: 1.69
Compound 3: the middle estimate sits 0.04 log units below what was measured; low and high end bracket the measured number.
By their numbers in this assay, from the lowest: compounds 1, 2 and 3 (each within the scatter of the next).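

In this assay, the ringless 3-(dimethylamino)propyl in place of the ring pyrrolidin-1-yl, on a saturated chain carbon, three bonds along the chain from an oxygen on an aromatic ring, gives only a small step (a number 0.12 log units higher from compound 1 to compound 3 (within the scatter)). The ringless amine end also stays close to the piperidine-bearing chain (a number 0.04 log units higher from compound 2 to compound 3 (within the scatter)), so this read-out does not separate ring from open chain among these compounds. Nothing at hand accounts for this closeness. On these data alone, whether a morpholine end or a carboxylic acid at the chain end would stay equally close remains open.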